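Swapping the Amine Ring: Compound 2 to Compound 3

A few compounds are considered here, and "the series" means these few. Any claim that something is new, unique, unknown or untested is made for them only; others in the source may bear on it.

Measured compounds:
compound 1 `CCCn1c(-c2ccccc2)nc2c(NC3CCC3)ncnc21`: 774 nM
compound 2 `Cn1c(-c2ccccc2)nc2c(NC3CCOC3)ncnc21`: 13300 nM

Of the compounds shown here, two have been measured in a functional assay on CHO cells for antagonist activity at adenosine receptor A2b (Homo sapiens), read by 33P incorporation, with a stated time of 20 min; on this read-out higher numbers stand for weaker inhibition and lower numbers for stronger inhibition. Compound 1 `CCCn1c(-c2ccccc2)nc2c(NC3CCC3)ncnc21` gives 774 nM in this assay, and compound 2 `Cn1c(-c2ccccc2)nc2c(NC3CCOC3)ncnc21` gives 13300 nM. Compound 2 therefore holds the higher of the two numbers, meaning weaker inhibition, and its gap to compound 1 lies beyond the usual scatter. Within the data shown here, the two compounds differ in more than one place, so no single step connects them.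

Compound 3 `Cn1c(-c2ccccc2)nc2c(NC3CCC3)ncnc21` has not yet been measured. It arises from compound 2 by one change: cyclobutyl in place of oxolan-3-yl on a nitrogen on an aromatic ring. Among the measured compounds shown here, no measured pair shows this same change, so the direction must be judged from the only related comparison at hand. Compound 1 also carries the cyclobutyl group and gives 774 nM, yet it differs from compound 3 in another place too, so it is only a rough guide. A step toward a lower number, meaning stronger inhibition, is expected for compound 3 a 4.4-fold lower number from compound 2 to compound 3 (0.65 log units; beyond the scatter), of a size beyond the scatter. The estimate for compound 3 in this assay is 3000 nM, with a range from 800 nM to 12000 nM.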

Compound 3, inhibition constant: 3730 nM
Beside the measured number, compound 3's estimate is 1.2-fold (0.09 log units) below it; low and high end bracket the measured number.
By their numbers in this assay, from the lowest: compound 1; then compound 3; then compound 2.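

In this assay, the change from oxolan-3-yl to cyclobutyl on a nitrogen on an aromatic ring gives a 3.6-fold lower number from compound 2 to compound 3 (0.55 log units; beyond the scatter). This shows that the group on that nitrogen matters on its own, since the rest of the molecule stays the same, whereas the earlier gap between compound 1 and compound 2 mixed two changes. The second change can now also be read alone: hydrogen in place of ethyl on a saturated chain carbon bound to an aromatic nitrogen gives a 4.8-fold higher number from compound 1 to compound 3 (0.68 log units; beyond the scatter), so the length of that chain matters too, and no data here explain either step.

The cyclobutyl step changes ring size and removes the ring oxygen at once, so the compounds shown cannot tell these two differences apart; cyclopentyl on the same nitrogen, a five-membered ring of carbon only, would separate them. On these data alone, how far the chain trend runs also stays open, since a butyl chain in place of the propyl chain of compound 1 could continue the trend or reverse it.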